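Phenyl Replaced by Dimethylcarbamoyl: Expected Cytotoxicity

The source may report more compounds than this note shows. Statements on the series, on what has been measured and on what is new or still open speak of the compounds shown alone.

Compound 1 `Nc1cc(-c2ccccc2)ccc1Cn1cncc1CNc1ccc(Cl)c(-c2ccccc2)c1`: in a toxicity assay on NIH3T3 cells (Mus musculus) for cytotoxicity, read by resazurin assay (on this read-out higher numbers stand for an effect only at larger amounts of compound and lower numbers for an effect already at smaller amounts), compound 1 reaches only the limit > 1000 nM.
Compound 2 `c1ccc(-c2ccc(Cn3cncc3CNc3ccc(-c4ccccc4)c(-c4ccccc4)c3)cc2)cc1`: in this assay compound 2 reaches only the limit > 10000 nM.
Compound 3 `c1ccc(Cn2cncc2CNc2cccc(-c3ccncc3)c2)cc1`: in this assay compound 3 reaches only the limit > 1000 nM.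

None of the three gives a number; all stand at limits. Compound 2 sits at the higher one, (the limit of > 10000 nM in this assay, at which 1 of the 3 values shown sits), while the two others sit at the lower one, (the limit of > 1000 nM in this assay, at which 2 of the 3 values shown sit). Compound 4 `CN(C)C(=O)c1ccc(NCc2cncn2Cc2ccc(-c3ccccc3)cc2)cc1-c1ccccc1` differs from compound 2 in a single place: dimethylcarbamoyl in place of phenyl on an aromatic carbon. Going by the values given here, no measured pair differs in one place, so no measured step guides this change. With every value a limit, compound 4 is expected to stand at a limit too. For compound 4 the expected step is a number no higher from compound 2 to compound 4 (the limit leaves the size open), none beyond the usual scatter. Compound 4 is expected to give 10000 nM, between 3000 nM and 30000 nM.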

Compound 4, half-maximal effective concentration: > 1000 nM
Compound 4 was reported as a limit; the forecaster's own chance of this, stated with the estimate: 80%; the middle value lies beyond the limit too.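

Compound 2 and compound 4 both stand at limits, so no step can be read for dimethylcarbamoyl in place of phenyl. The compounds shown leave open at what concentration any of them would give a measurable effect in this assay.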